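Swapping the ring on the triple bond: from pyridyl to fluoropyridyl

A few compounds are considered here, and "the series" means these few. Any claim that something is new, unique, unknown or untested is made for them only; others in the source may bear on it.

Three compounds share one core and differ only in the ring attached to a triple-bonded carbon. Compound 1 `C[C@@H](NC(=O)c1ccc(C#Cc2ccccc2)cn1)C(C)(C)O` carries a phenyl there and in an ADME assay on HEK293 cells for agonist activity at metabotropic glutamate receptor 5 (Rattus norvegicus), read by fluorescence and calcium flux (on this read-out higher numbers stand for larger maximal responses and lower numbers for smaller maximal responses), compound 1 gives 43.2%. Compound 2 `C[C@@H](NC(=O)c1ccc(C#Cc2ccc(F)cc2F)cn1)C(C)(C)O` carries a 2,4-difluorophenyl and gives 38.2%; the step of a number 5 percentage points lower from compound 1 to compound 2 (within the scatter) is small. Compound 3 `C[C@@H](NC(=O)c1ccc(C#Cc2ccncc2)cn1)C(C)(C)O` carries a pyridin-4-yl and gives 22.4%, the lowest of the three numbers: the steps of a number 20.8 percentage points lower from compound 1 to compound 3 (beyond the scatter) and a number 15.8 percentage points lower from compound 2 to compound 3 (beyond the scatter) both exceed the scatter.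

Compound 4 `C[C@@H](NC(=O)c1ccc(C#Cc2cccc(F)n2)cn1)C(C)(C)O` is the next variant: 6-fluoropyridin-2-yl in place of pyridin-4-yl on a triple-bonded carbon. Two things bear on this. Putting a nitrogen into the ring lowered the response, as the step from compound 1 to compound 3 shows, while adding fluorines changed little, as the step from compound 1 to compound 2 shows. Compound 4 keeps a ring nitrogen but moves it and adds a fluorine, so the expectation is a response near that of compound 3, perhaps somewhat higher but not clearly beyond the scatter. Compound 4 is therefore estimated at 30%, with a range from 15% to 48%, which is an expected step of a number 7.6 percentage points higher from compound 3 to compound 4 (within the scatter).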

Compound 4, largest response reached (reported as efficacy), in percent of the reference or control that the assay uses: 8.3%
The estimate for compound 4 lay 21.7 percentage points above the measured number, and the stated range ends above it.
By their numbers in this assay, from the lowest: compound 4; then compound 3; then compounds 2 and 1 (each within the scatter of the next).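

The ring on the triple-bonded carbon has more range than compounds 1 to 3 could show: in this assay replacing the pyridin-4-yl gives a number 14.1 percentage points lower from compound 3 to compound 4 (beyond the scatter) and so a ring nitrogen does not fix the response at a single level. Against the rings without nitrogen the gap widens, with a number 29.9 percentage points lower from compound 2 to compound 4 (beyond the scatter) and with a number 34.9 percentage points lower from compound 1 to compound 4 (beyond the scatter) as the largest step in this set. Fluorine also gives no simple rule across rings: the two fluorines of compound 2 left its number within the scatter of compound 1, yet compound 4, which carries a fluorine on a pyridine ring, now stands lowest of the four.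

Going by these compounds, compound 4 differs from compound 3 both in where the ring nitrogen lies and in the added fluorine, so the share of each remains open, as does the outcome for a plain pyridin-2-yl or for a 6-aminopyridin-2-yl or 6-methoxypyridin-2-yl on the same carbon. Nothing measured here accounts for the fall in response.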